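This account rests on a few compounds, and the source may have more. Where it says the series, first, only, none or still open, it means among the compounds named here.

Measured compounds in a functional assay on MGC-803 cells (Homo sapiens) for cytotoxicity, read by MTT assay, with a stated time of 72 h; a higher number here means a weaker inhibitor, a lower number a stronger inhibitor:
compound 1, `FC(F)(F)c1ccc(CSc2nc(Nc3cccc(C(F)(F)F)c3)c3ccccc3n2)cc1`, compound 1 gives 15100 nM;
compound 2, `O=[N+]([O-])c1cccc(Nc2nc(SCc3ccc(C(F)(F)F)cc3)nc3ccccc23)c1`; for compound 2 the assay reports only a limit, > 50000 nM;
compound 3, `O=[N+]([O-])c1ccc(Nc2nc(SCc3ccc(C(F)(F)F)cc3)nc3ccccc23)cc1`, compound 3 gives 8170 nM.

Compound 3 and compound 2 share a core and differ in 4-nitrophenyl in place of 3-nitrophenyl on a nitrogen on an aromatic ring, the step being an at least 6.1-fold lower number from compound 2 to compound 3 (0.78 log units; beyond the scatter). Compound 1 and compound 3 lie close together: a 1.8-fold lower number from compound 1 to compound 3 (0.27 log units; within the scatter).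

The change of interest, trifluoromethyl in place of nitro, has one measured case, from compound 2 to compound 1: trifluoromethyl in place of nitro on an aromatic carbon, with an at least 3.3-fold lower number from compound 2 to compound 1 (0.51 log units; beyond the scatter). That step is only a bound because of the limit of > 50000 nM in this assay, at which 1 of the 3 values shown sits.

Compound 4, `FC(F)(F)c1ccc(CSc2nc(Nc3ccc(C(F)(F)F)cc3)c3ccccc3n2)cc1`, is unmeasured; it differs from compound 3 by trifluoromethyl in place of nitro on an aromatic carbon. The place lines differ in one respect, meta to a large group for the earlier pair and para to a large group here, so this is the same kind of change rather than the same change.

Since the measured case from compound 2 to compound 1 shows an at least 3.3-fold lower number from compound 2 to compound 1 (0.51 log units; beyond the scatter), and compound 3 already gives 8170 nM, a smaller lowering is expected for compound 4: a 1.8-fold lower number from compound 3 to compound 4 (0.26 log units; within the scatter). Compound 4 is estimated at 4500 nM, between 1500 nM and 14000 nM.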

Compound 4, half-maximal inhibitory concentration: 6170 nM
Compound 4: the middle estimate sits 1.4-fold (0.14 log units) below what was measured; low and high end bracket the measured number.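

In this assay, trifluoromethyl in place of nitro, here para to a large group, gives a 1.3-fold lower number from compound 3 to compound 4 (0.12 log units; within the scatter), so on this core the change does not separate the two compounds. This does not show that the change carries from one core to another with a fixed size, nor that its size differs between the two cases, which leaves the comparison unresolved: the same change on two cores in this assay, an at least 3.3-fold lower number (0.51 log units; beyond the scatter) from compound 2 to compound 1 and a 1.3-fold lower number (0.12 log units; within the scatter) from compound 3 to compound 4; the limit leaves it open whether they differ Two further steps replace the whole group on the nitrogen, a 2.4-fold lower number from compound 1 to compound 4 (0.39 log units; beyond the scatter) and an at least 8.1-fold lower number from compound 2 to compound 4 (0.90 log units; beyond the scatter), and the second of these is only a bound: the limit of > 50000 nM in this assay, at which 1 of the 4 values shown sits.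

The compounds shown leave open how other groups at this place on the ring would read, such as a nitrile, an amine or a carboxylic acid. They also leave open whether the change would read the same with a longer chain on the sulfur, or on cells other than those tested here.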